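This account rests on a few compounds, and the source may have more. Where it says the series, first, only, none or still open, it means among the compounds named here.

In a functional assay on a cell-free system (plasma, Homo sapiens), with a stated time of 3 min (on this read-out higher numbers stand for weaker inhibition and lower numbers for stronger inhibition), compound 1 (`O=C(NCc1cc(Cl)ccc1-n1cnnn1)[C@@H]1CC=NN1C(=O)[C@H](O)Cc1ccccc1`) gives 1400 nM, compound 2 (`CCCC[C@@H](O)C(=O)N1C[C@H]2C[C@H]2[C@H]1C(=O)NCc1cc(Cl)ccc1-n1cnnn1`) gives 750 nM and compound 3 (`CC(C)(C)C[C@@H](O)C(=O)N1[C@@H]2C[C@@H]2C[C@H]1C(=O)NCc1cc(Cl)ccc1-n1cnnn1`) gives 520 nM. Compound 2 thus lies within the usual scatter of both other compounds. Compound 4 (`CC1(C[C@@H](O)C(=O)N2C[C@H]3C[C@H]3[C@H]2C(=O)NCc2cc(Cl)ccc2-n2cnnn2)CC1`) differs from compound 2 by one change: 1-methylcyclopropyl in place of propyl on a saturated chain carbon, two bonds along the chain from a carbonyl carbon and an oxygen on a saturated carbon. Within the data shown here, no measured pair shows the effect of a single change, so the data offer only a loose guide. That guide is compound 3, whose side chain is also branched, at 520 nM. The expected change is small, toward stronger inhibition and probably within the scatter: a 1.8-fold lower number from compound 2 to compound 4 (0.25 log units; within the scatter). Compound 4 is estimated at 420 nM, with an expected range of 170 nM to 1000 nM.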

Compound 4, half-maximal inhibitory concentration: 500 nM
Compound 4: the middle estimate sits 1.2-fold (0.08 log units) below what was measured; measured number inside the range.
By their numbers in this assay, from the lowest: compounds 4, 3, 2 and 1 (each within the scatter of the next, the first and the last beyond it).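

In this assay, among these compounds, swapping propyl for 1-methylcyclopropyl on this saturated chain carbon gives a 1.5-fold lower number from compound 2 to compound 4 (0.18 log units; within the scatter) and thus provides the first comparison that isolates a single change. At this position, a branched group carrying a three-membered ring is tolerated, with the number staying within the scatter of the straight chain. Nothing measured here explains this result. From the compounds shown here alone, it remains open whether a longer chain, a phenyl ring, an amine or a carboxylic acid at this position would move the number beyond the scatter.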